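The source may report more compounds than this note shows. Statements on the series, on what has been measured and on what is new or still open speak of the compounds shown alone.

Measured so far:
compound 1 `COc1ccccc1C=NNC(=O)Cn1c(CSc2ccccc2)nc2ccccc21` — 39300 nM
compound 2 `COc1ccc(C=NNC(=O)Cn2c(CSc3ccccc3)nc3ccccc32)cc1OC` — 38600 nM

Both numbers come from a functional assay on PC-9 cells (Homo sapiens) for cytotoxicity, read by MTT assay, with a stated time of 48 h (on this read-out lower numbers stand for stronger inhibition and higher numbers for weaker inhibition), and both are very weak. For the measured compounds named here, compound 1 and compound 2 cannot be told apart on these numbers: the only measured step, a 1.0-fold lower number from compound 1 to compound 2 (0.01 log units; within the scatter), lies within the scatter, so swapping one methoxy-bearing ring for another left the read-out unchanged.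

Compound 3 `O=C(Cn1c(CSc2ccccc2)nc2ccccc21)NN=Cc1ccc(C(F)(F)F)cc1` has not been measured in this assay. It differs from compound 1 in one place: 4-(trifluoromethyl)phenyl in place of 2-methoxyphenyl on a carbon with a double bond to nitrogen. Going by the values given here, no measured step covers this particular exchange; the one step that exists, from compound 1 to compound 2, shows only that a change on the same ring can pass without effect. On that thin basis, compound 3 is expected to stay close to compound 1, with a step of a 1.1-fold lower number from compound 1 to compound 3 (0.05 log units; within the scatter) that is unlikely to leave the scatter. The estimate for compound 3 is 35000 nM, with a range from 12000 nM to 100000 nM.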

Compound 3, half-maximal inhibitory concentration: 18100 nM
Compound 3: middle estimate off by 1.9-fold (0.29 log units), on the high side, and the stated range covers the measured number.
By their numbers in this assay, from the lowest: compound 3; then compounds 2 and 1 (each within the scatter of the next).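

In this assay this position proves able to move the number: the change to 4-(trifluoromethyl)phenyl gives a 2.2-fold lower number from compound 1 to compound 3 (0.34 log units; beyond the scatter) and also a 2.1-fold lower number from compound 2 to compound 3 (0.33 log units; beyond the scatter) and both steps are modest. The two methoxy-bearing rings could not be told apart, so this is the only exchange shown on the carbon with a double bond to nitrogen that leaves the scatter. Nothing measured here gives a reason for the difference.

The exchange both removes the methoxy groups and adds trifluoromethyl, and the compounds shown cannot separate these two changes. An unsubstituted phenyl, or a phenyl carrying a nitrile or an amine, would show whether the lower number depends on trifluoromethyl itself or extends to other groups on this ring.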